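The compounds below may be only part of what the source reports. "The series", "measured", "known", "first", "only" and "open" are said of these compounds alone.

Three compounds of one series have so far been run in a functional assay on PC-12 cells (Rattus norvegicus) for cytotoxicity, read by MTT assay, with stated times of 2 h and 24 h, tested at 10 uM; on this read-out lower numbers stand for a weaker effect and higher numbers for a stronger effect at the one concentration tested. Compound 1 `Oc1cc(C(F)(F)F)ccc1-c1nc(-c2ccccc2O)n(-c2ccc(I)cc2)n1` gives 105%. Compound 2 `N#Cc1ccc(-n2nc(-c3ccc(C(F)(F)F)cc3O)nc2-c2ccccc2O)cc1` gives 98.9%. Compound 3 `Oc1cc(C(F)(F)F)ccc1-c1nc(-c2ccccc2O)n(-c2cccc(F)c2)n1` gives 98.3%. The steps between them are all small: a number 6.1 percentage points lower from compound 1 to compound 2 (within the scatter), a number 6.7 percentage points lower from compound 1 to compound 3 (within the scatter), and a number 0.6 percentage points lower from compound 2 to compound 3 (within the scatter). Compound 3 therefore sits with compound 2 and with compound 1 inside the usual scatter, set apart from neither.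

Compound 4 `Oc1cc(C(F)(F)F)ccc1-c1nc(-c2ccccc2O)n(-c2ccc(F)cc2F)n1` differs from compound 3 in one place: 2,4-difluorophenyl in place of 3-fluorophenyl on an aromatic nitrogen. The measured steps that touch the group on the aromatic nitrogen are a number 6.7 percentage points lower from compound 1 to compound 3 (within the scatter) and a number 0.6 percentage points lower from compound 2 to compound 3 (within the scatter), both within the scatter, and neither of them puts 2,4-difluorophenyl in place of 3-fluorophenyl. On this basis no step beyond the scatter is expected in this assay for compound 4, in either direction. The estimated read-out for compound 4 is 99%, with a range from 88% to 110%. The expected step, a number 0.7 percentage points higher from compound 3 to compound 4 (within the scatter), stays within the scatter.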

Compound 4, a percentage reported as activity, at one concentration (the size of the read-out at that concentration, not a potency): 97.9%
The estimate for compound 4 lay 1.1 percentage points above the measured number, within the range that was stated.
By their numbers in this assay, from the lowest: compounds 4, 3, 2 and 1 (each within the scatter of the next).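

Notes on the group on the aromatic nitrogen: 2,4-difluorophenyl joins 3-fluorophenyl, 4-cyanophenyl and 4-iodophenyl as a fourth aryl group at this position in this assay, and the read-out stays inside the scatter against all three: a number 0.4 percentage points lower from compound 3 to compound 4 (within the scatter), a number 1 percentage points lower from compound 2 to compound 4 (within the scatter) and a number 7.1 percentage points lower from compound 1 to compound 4 (within the scatter). A phenyl group carrying two fluorine atoms therefore sets itself apart from none of the singly substituted phenyl groups, so the flat picture at this position now covers four compounds. Nothing available bears on why this position gives such uniform numbers.

As far as these compounds go, it remains open whether a non-aromatic group at this nitrogen, such as a longer alkyl chain, or a phenyl group carrying an amine or a carboxylic acid, would stay inside the scatter. The compounds shown also leave open what replacing either hydroxyl group or the trifluoromethyl group does to this read-out.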